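The source may report more compounds than this note shows. Statements on the series, on what has been measured and on what is new or still open speak of the compounds shown alone.

In a functional assay on T47D cells (Homo sapiens) for cytotoxicity, read by colorimetric assay and MTT assay (a higher number here means a weaker inhibitor, a lower number a stronger inhibitor), compound 1 `COc1cc(OC)c2cc(-c3ccccc3)c(O)nc2c1` gives 10000 nM. Compound 2 `COc1ccc(-c2cc3c(OC)cc(OC)cc3n(CC#N)c2=O)cc1` gives 10000 nM, which puts it level with compound 1 within the scatter. Compound 3 `CCN(CC)C(=O)CCn1c(=O)c(-c2ccc(OC)cc2)cc2c(OC)cc(OC)cc21` differs from compound 2 in one place, with (diethylcarbamoyl)methyl in place of cyano on a saturated chain carbon bound to an aromatic nitrogen. Within the data shown here, the compounds measured so far include no pair that differs in one place, so the data do not show directly what such a change does in this assay. Among the measured compounds shown here, the only guide is that compound 2 stands at 10000 nM, level with compound 1, and so no step beyond the scatter is expected, in either direction. The estimated step is no change at the digits printed from compound 2 to compound 3 (within the scatter). Compound 3 is expected at 10000 nM, with an estimated range of 3000 nM to 20000 nM.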

Compound 3, half-maximal inhibitory concentration: 10000 nM
Estimate against measurement, compound 3: no gap at the digits printed; measured number inside the range.
By their numbers in this assay, from the lowest: compounds 1, 2 and 3 (each within the scatter of the next).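

In this assay, among these compounds, putting (diethylcarbamoyl)methyl in place of cyano on a saturated chain carbon bound to an aromatic nitrogen gives no change at the digits printed from compound 2 to compound 3 (within the scatter), the first step that can be read at this place. The read-out therefore stays the same when the nitrile gives way to a larger, ring-free group carrying a carbonyl, so this exchange does not separate the two compounds in this assay. Nothing in hand explains this result.

On these data alone, compound 3 gives 10000 nM, and it remains open whether a tertiary amine, a carboxylic acid or a longer chain at this place would move that number. The compounds shown also leave open whether any group at this place would produce a step beyond the scatter.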